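Replacing the pyrazole of compound 2 with a hydroxypropyl chain

A few compounds are considered here, and "the series" means these few. Any claim that something is new, unique, unknown or untested is made for them only; others in the source may bear on it.

Compound 1 `Cc1ccc(OCC(=O)N(Cc2cccs2)c2c(C)n[nH]c2C)cc1`: 0.3 nM
Compound 2 `Cc1ccc(OCC(=O)N(Cc2cccs2)c2cnn(C)c2)cc1`: 63000 nM

In an assay on HEK293 cells for agonist activity at transient receptor potential cation channel subfamily M member 8 (Homo sapiens), read by fluorescence and calcium flux, with a stated time of 15 min (a higher number here means that more compound is needed for the effect, a lower number that less compound is needed), compound 2 gives the higher of the two numbers shown, because a 210000-fold higher number from compound 1 to compound 2 (5.32 log units; beyond the scatter) separates it from compound 1. Compound 3 `Cc1ccc(OCC(=O)N(CCCO)Cc2cccs2)cc1` differs from compound 2 by 3-hydroxypropyl in place of 1-methyl-1H-pyrazol-4-yl on an amide-type nitrogen. Among the measured compounds shown here, the only measured step bearing on this position is that from compound 1 to compound 2, which shows that altering the group on this nitrogen can move this assay enormously. For the measured compounds named here, no measured step covers a chain in place of a ring here, so the direction is uncertain; compound 3 is expected to stay weak, with a 1.3-fold higher number from compound 2 to compound 3 (0.10 log units; within the scatter). Compound 3 is estimated at 80000 nM, with a range from 8000 nM to 500000 nM.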

Compound 3, half-maximal effective concentration: 3000 nM
For compound 3 the middle estimate is 27-fold (1.43 log units) above the measured one; measured number below the stated range.
By their numbers in this assay, from the lowest: compound 1; then compound 3; then compound 2.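

In this assay, a ring on the amide-type nitrogen is not needed for the number to fall: 3-hydroxypropyl, which has no ring, gives a 21-fold lower number from compound 2 to compound 3 (1.32 log units; beyond the scatter). The chain still stays far from the 3,5-dimethyl-1H-pyrazol-4-yl group, with a 10000-fold higher number from compound 1 to compound 3 (4.00 log units; beyond the scatter). No available evidence explains either step.

The compounds shown leave open whether the hydroxy group of the chain contributes to this gain. A plain propyl chain, a 3-aminopropyl chain or a longer hydroxyalkyl chain on this nitrogen could each give a different number.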